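A few compounds are considered here, and "the series" means these few. Any claim that something is new, unique, unknown or untested is made for them only; others in the source may bear on it.

Compound 1 `Cc1nc(SCC(=O)Nc2nc(-c3ccc(Cl)cc3)cs2)n(Nc2ccccc2)c1C` was examined in a functional assay on SK-MEL-2 cells (Homo sapiens) for antiproliferative activity, read by sulforhodamine B assay, with a stated time of 48 h (on this read-out lower numbers stand for stronger inhibition of growth and higher numbers for weaker inhibition of growth), where compound 1 gives 27600 nM. Going by the values given here, only one other compound has a number on this read-out: compound 2 `Cc1ccc(Nn2c(SCC(=O)Nc3nc(-c4ccccc4)cs3)nc(C)c2C)cc1`, which in this assay gives 35300 nM. Among the compounds with values here, the two values lie within the scatter of each other, so compound 1 cannot be separated from compound 2; it simply stands alongside compound 2 among the two numbers known.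

The next compound, compound 3 `COc1ccc(Nn2c(SCC(=O)Nc3nc(-c4ccc(Cl)cc4)cs3)nc(C)c2C)cc1`, keeps the core of compound 1 and differs from it in a single place: methoxy in place of hydrogen on an aromatic carbon. Within the data shown here, no pair of measured compounds isolates such a change, so the data contain nothing that shows what this methoxy group does on this read-out. Compound 2 differs from compound 1 in more than one place, and its value beside that of compound 1 shows only that the two are within the scatter.

With no guidance from a measured step, the step of a 1.1-fold higher number from compound 1 to compound 3 (0.04 log units; within the scatter) is expected to be none beyond the scatter. Compound 3 is therefore estimated at 30000 nM, with a range from 12000 nM to 75000 nM.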

Compound 3, concentration for total growth inhibition: 66800 nM
Estimate against measurement, compound 3: 2.2-fold (0.35 log units) below, within the range that was stated.
By their numbers in this assay, from the lowest: compounds 1, 2 and 3 (each within the scatter of the next, the first and the last beyond it).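

Going from anilino to (4-methoxyphenyl)amino, with methoxy in place of hydrogen on an aromatic carbon, gives a 2.4-fold higher number from compound 1 to compound 3 (0.38 log units; beyond the scatter) in this assay. Going by these compounds alone, this is the first measured step that isolates a single change, and it shows that this place, para to a large group, is not indifferent to substitution: here the added methoxy goes with weaker inhibition of growth. The finding rests on one pair of compounds, and nothing measured here bears on why methoxy has this effect.

The compounds shown leave open whether other groups at the same place, such as a fluorine atom, a hydroxyl, an amine or a carboxylic acid, would follow methoxy or depart from it, and whether a longer chain such as ethoxy would take the number further in the same direction. They also leave open whether methoxy would give a similar step on the scaffold of compound 2, which lacks the chlorine carried by compound 1 and compound 3.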